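The source may report more compounds than this note shows. Statements on the series, on what has been measured and on what is new or still open speak of the compounds shown alone.

Of the compounds shown here, three have been tested in an assay for inhibition of protein disulfide-isomerase (Homo sapiens), with a stated time of 1 h; on this read-out lower numbers stand for stronger inhibition and higher numbers for weaker inhibition. Within the data shown here, compound 1 `Cc1ccnc(NC(c2ccc(C(F)(F)F)cc2)c2ccc3cccnc3c2O)c1` gives 26500 nM and is the only one with an actual number. Compound 2 `CN(C)c1cccc(C(c2ccc(F)cc2)N2CCCCC2)c1O` reaches only a limit of the assay, > 30000 nM. Compound 3 `Oc1ccc2scnc2c1C(c1ccc(F)cc1)N1CCCCC1` likewise reaches only a limit, > 100000 nM. Compound 4 `Cc1ccnc(NC(c2cc(C)ccc2C)c2ccc3cccnc3c2O)c1` has not been measured; it differs from compound 1 in one place: 2,5-dimethylphenyl in place of 4-(trifluoromethyl)phenyl on a saturated chain carbon bound to an aromatic carbon and a nitrogen on an aromatic ring. Among the measured compounds shown here, no measured pair of compounds isolates this kind of change, so there is no direct guide to its size or direction. Since compound 1 at 26500 nM is already weak, the step is expected to stay within the usual scatter, a 1.1-fold higher number from compound 1 to compound 4 (0.05 log units; within the scatter). Compound 4 is therefore expected to give about 30000 nM, between 10000 nM and 100000 nM.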

Compound 4, half-maximal inhibitory concentration: > 40000 nM
Compound 4: a limit, no number; the forecaster's own chance of this, stated with the estimate: 40%; middle value at least 1.3-fold (0.12 log units) away from the limit.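

Placing 2,5-dimethylphenyl where compound 1 carries 4-(trifluoromethyl)phenyl gives, in this assay, an at least 1.5-fold higher number from compound 1 to compound 4 (0.17 log units; that floor lies within the scatter), so this change at this position brings no visible gain in inhibition. Compound 4 gives only a limit of the assay, and the true size of the step stays unknown because of it: the limit of > 40000 nM in this assay, at which 1 of the 4 values shown sits.

The compounds shown cannot separate the loss of the trifluoromethyl group from the arrival of the methyl groups. On these data alone, it also remains open whether an unsubstituted phenyl, or a phenyl ring bearing an amine or a carboxylic acid, would give stronger inhibition at this position.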